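The compounds below may be only part of what the source reports. "The series", "measured", "known", "first", "only" and "open" are said of these compounds alone.

Values in a functional assay on HT-29 cells (Homo sapiens) for inhibition, read by MTT assay, with a stated time of 72 h (on this read-out higher numbers stand for weaker inhibition and lower numbers for stronger inhibition), for the three measured compounds:

Compound 1 `COc1cc(Oc2cccc(Nc3ccccc3)c2)cc(OC)c1CNCc1ccc(Br)cc1`: 3060 nM
Compound 2 `COc1cc(Oc2cccc(Nc3ccccc3)c2)cc(OC)c1CNCc1ccc(Cl)cc1`: 3350 nM
Compound 3 `COc1ccc(CCCNCc2c(OC)cc(Oc3cccc(Nc4ccccc4)c3)cc2OC)cc1`: 3320 nM

All three numbers sit close together. Compound 3 is separated from its neighbours only by steps within the scatter: a 1.0-fold lower number from compound 2 to compound 3 (0.00 log units; within the scatter) and a 1.1-fold higher number from compound 1 to compound 3 (0.04 log units; within the scatter). The two changes made so far both touch the group carried on the amine nitrogen, and neither moved the number: a 1.1-fold higher number from compound 1 to compound 2 (0.04 log units; within the scatter), a 1.1-fold higher number from compound 1 to compound 3 (0.04 log units; within the scatter), a 1.0-fold lower number from compound 2 to compound 3 (0.00 log units; within the scatter).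

Compound 4 `COc1cc(Oc2cccc(Nc3ccccc3)c2)cc(OC)c1CCO` is a different kind of change: hydroxymethyl in place of (3-(4-methoxyphenyl)propyl)amino on a saturated chain carbon bound to an aromatic carbon. No measured step removes the amine and its chain, so nothing shown speaks directly to this move; the measured steps only say that swapping what hangs on the amine is inert. With the whole chain gone, a weakening beyond the scatter is expected for compound 4, giving an estimated step of a 2.7-fold higher number from compound 3 to compound 4 (0.43 log units; beyond the scatter). In this assay compound 4 is therefore expected to give about 9000 nM, with a range from 2500 nM to 30000 nM.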

Compound 4, half-maximal inhibitory concentration: 13900 nM
Compound 4: middle estimate off by 1.5-fold (0.19 log units), on the low side; the range from low to high includes it.
By their numbers in this assay, from the lowest: compounds 1, 3 and 2 (each within the scatter of the next); then compound 4.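

In this assay, for the compounds shown here, swapping the amine and all it carries for a plain hydroxymethyl is the first change here to go beyond the scatter, and it does so from each of the three amines (first a 4.2-fold higher number from compound 3 to compound 4 (0.62 log units; beyond the scatter), then a 4.1-fold higher number from compound 2 to compound 4 (0.62 log units; beyond the scatter), and finally a 4.5-fold higher number from compound 1 to compound 4 (0.66 log units; beyond the scatter)). So while the groups on the amine nitrogen could be exchanged without any shift beyond the scatter, removing the whole unit at this saturated chain carbon bound to an aromatic carbon does weaken inhibition, though only modestly. Nothing available explains this step.

The change removes the nitrogen and the aromatic ring together, so the compounds shown cannot tell which of the two matters. A simple amino group in place of the hydroxymethyl, or a carboxylic acid there, would help to separate these contributions.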